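The compounds below may be only part of what the source reports. "The series", "measured", "known", "first", "only" and "open" are said of these compounds alone.

Working notes on the series in a physicochemical assay for lipophilicity, using the shake flask method; a lower number here means a more polar compound, a higher number a more lipophilic compound.

Three compounds carry measured numbers. Compound 1 `C[C@H](Oc1ccc2ncc(/C=C/c3nn[nH]n3)c(C(F)F)c2c1)c1c(Cl)cccc1Cl` gives 3.3 in this assay. Compound 2 `C[C@H](Oc1nccc(N(c2nc(C(=O)O)cs2)C2CC2)n1)c1c(Cl)ccc(F)c1Cl` gives 2.6 in this assay. Compound 3 `C[C@H](Oc1ccc2ncc(S(=O)(=O)CC(=O)O)c(C3CC3)c2c1)c1c(Cl)ccc(F)c1Cl` gives 2.5 in this assay, the lowest of the three numbers; its gap to compound 2 lies within the scatter, so those two cannot be ordered, while compound 1 stands beyond the scatter above compound 3. For the measured compounds named here, no pair of measured compounds differs in only one place, so no measured single step is available for calibration.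

Compound 4 `C[C@H](Oc1ccc2ncc(/C=C/C(=O)O)c(C3CC3)c2c1)c1c(Cl)ccc(F)c1Cl` has not yet been measured in this assay. It differs from compound 3 in a single place: 2-carboxyethenyl in place of (carboxymethyl)sulfonyl on an aromatic carbon.

Going by the values given here, with no measured step to lean on, the expectation rests on the change itself and on compound 1. Among the compounds with values here, compound 1 is the only measured compound carrying an ethenyl group on the core and gives 3.3, but it differs from compound 4 in more than one place and sets only a loose bearing. The step from compound 3 to compound 4 in this assay is expected to be upward and beyond the scatter, at a number 0.50 log units higher from compound 3 to compound 4 (beyond the scatter). Compound 4 is therefore estimated at 3, with a range from 2.5 to 3.5.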

Compound 4, distribution coefficient: 4.1
For compound 4 the middle estimate is 1.10 log units below the measured one; the measured number lies above the stated range.
By their numbers in this assay, from the lowest: compounds 3 and 2 (each within the scatter of the next); then compound 1; then compound 4.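

At the aromatic carbon ortho to a cyclopropyl group, the series now has its first measured single step: in this assay, 2-carboxyethenyl in place of (carboxymethyl)sulfonyl gives a number 1.60 log units higher from compound 3 to compound 4 (beyond the scatter). For the compounds shown here, with the rest of the structure held fixed, the group on this one carbon is thus enough to move the number by a large amount, which the earlier compounds, all differing in more than one place, could not show. Both groups carry a carboxy end, so that end alone does not set the number at this position, and nothing measured here accounts for the size of the step.

This single step does not separate the departure of the sulfonyl from the arrival of the ethenyl, and it does not show whether a step of this size would recur with another group in place of the cyclopropyl or on another core. From the compounds shown here alone, how an amine, an amide or a longer saturated chain on the same aromatic carbon would stand in this assay relative to compound 3 and compound 4 remains open.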